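Notes on the phenoxy series: extending compound 1 to compound 4

This account rests on a few compounds, and the source may have more. Where it says the series, first, only, none or still open, it means among the compounds named here.

Measured so far in an in vitro assay on SH-EP1 cells for displacement of a labelled ligand from Neuronal acetylcholine receptor; alpha4/beta2 (Homo sapiens); a higher number here means a weaker inhibitor, a lower number a stronger inhibitor:
- compound 1 `C1=C(c2cncc(Oc3ccccc3)c2)CC2CNCC1C2`: 0.7 nM
- compound 2 `FC(F)(F)c1cncc(C2=CC3CNCC(C2)C3)c1`: 0.7 nM
- compound 3 `COc1cc(C2=CC3CNCC(C2)C3)cnc1Cl`: 0.4 nM

Compound 1 stands level with compound 2 in this assay; together they give the highest two numbers of the three, and compound 3 gives a number that is lower, though that gap lies within the scatter. Among the measured compounds shown here, the one measured step, no change at the digits printed from compound 1 to compound 2 (within the scatter), exchanges the whole phenoxy group for trifluoromethyl and leaves the number unchanged within the scatter.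

Compound 4 `COc1ccc(Oc2cncc(C3=CC4CNCC(C3)C4)c2)cc1` keeps the phenoxy group of compound 1 and alters it: methoxy in place of hydrogen on an aromatic carbon. The same difference, cut one bond further out, reads phenyl to 4-methoxyphenyl; the methoxy sits para to a large group. For the measured compounds named here, no measured step touches the phenoxy ring itself, so none bears directly on this change. The step from compound 1 to compound 2 shows that the phenoxy group can be removed entirely without a change beyond the scatter, and no number here shows that a substituent on that ring would matter.

The expected step from compound 1 to compound 4 in this assay is therefore no change at the digits printed from compound 1 to compound 4 (within the scatter), none beyond the scatter. Compound 4 is estimated at 0.7 nM, with a range from 0.3 nM to 1.6 nM.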

Compound 4, inhibition constant: 1.4 nM
The estimate for compound 4 lay 2.0-fold (0.30 log units) below the measured number; low and high end bracket the measured number.
By their numbers in this assay, from the lowest: compounds 3, 1, 2 and 4 (each within the scatter of the next, the first and the last beyond it).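

In this assay, among the compounds shown here, methoxy in place of hydrogen on an aromatic carbon para to a large group gives a 2.0-fold higher number from compound 1 to compound 4 (0.30 log units; within the scatter), the first measured step that touches the phenoxy ring itself rather than removing it. The phenoxy ring of compound 1 therefore accepts a methoxy at this carbon without a change beyond the scatter, which the step of no change at the digits printed from compound 1 to compound 2 (within the scatter) could not show, as that step exchanges the whole group and leaves no substituted ring to read. Nothing among the compounds shown offers a measured reason for the size of this step, so it stands as an observation without an explanation.

This single substituent at a single carbon does not say how far the finding extends: a carboxylic acid, an amine or a longer chain such as butoxy at the same carbon could give a quite different number. Also open is whether methoxy on any other carbon of the phenoxy ring would stay within the scatter of compound 1, since the compounds shown hold no substituent anywhere else on that ring.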